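A few compounds are considered here, and "the series" means these few. Any claim that something is new, unique, unknown or untested is made for them only; others in the source may bear on it.

Working notes on the series. Compound 2 `O=C(O)CC1c2ccccc2N=C(c2ccccc2)N1c1ccccc1` gives 7.2% in a functional assay on cells (Oocyte) for inhibition of Voltage-dependent T-type calcium channel subunit alpha-1H (Homo sapiens), tested at 100 uM; a lower number here means less inhibition, a higher number more inhibition at the concentration tested (going by the name of the read-out). Compound 1 `O=C(O)CC1c2ccccc2N=C(N2CCCCC2)N1c1ccccc1` gives 8% in this assay; the change is piperidin-1-yl in place of phenyl on a carbon with a double bond to nitrogen and the step is a number 0.8 percentage points higher from compound 2 to compound 1 (within the scatter). Compound 3 `O=C(CC1c2ccccc2N=C(c2ccccc2)N1c1ccccc1)OCc1ccccc1` gives 14.2% in this assay; it differs from compound 2 by benzyl in place of hydrogen on an oxygen next to a carbonyl group, a step of a number 7 percentage points higher from compound 2 to compound 3 (within the scatter). Compound 4 `O=C(CC1c2ccccc2N=C(N2CCCCC2)N1c1ccccc1)OCc1ccccc1` has not yet been measured in this assay. It differs from compound 3 by piperidin-1-yl in place of phenyl on a carbon with a double bond to nitrogen. This is the same kind of change as that from compound 2 to compound 1, but the place lies two ring bonds from the ring atom that bears a (benzyloxycarbonyl)methyl group rather than a carboxymethyl group. For compound 4 the expected step is a number 0.8 percentage points higher from compound 3 to compound 4 (within the scatter), because the earlier step of this kind was a number 0.8 percentage points higher from compound 2 to compound 1 (within the scatter). Compound 4 is therefore estimated at 15%, between 5% and 25%.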

Compound 4, a percentage reported as inhibition, at one concentration (the size of the read-out at that concentration, not a potency): 15.6%
For compound 4 the middle estimate is 0.6 percentage points below the measured one, and the stated range covers the measured number.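

In this assay, piperidin-1-yl in place of phenyl gives a number 1.4 percentage points higher from compound 3 to compound 4 (within the scatter), which matches the earlier step on the other core: the same change on two cores in this assay, a number 0.8 percentage points higher (within the scatter) from compound 2 to compound 1 and a number 1.4 percentage points higher (within the scatter) from compound 3 to compound 4, 0.6 percentage points apart, within the scatter of two such steps. Benzyl in place of hydrogen on an oxygen next to a carbonyl group gives a number 7.6 percentage points higher from compound 1 to compound 4 (within the scatter), and this change also carries across cores: the same change on two cores in this assay, a number 7 percentage points higher (within the scatter) from compound 2 to compound 3 and a number 7.6 percentage points higher (within the scatter) from compound 1 to compound 4, 0.6 percentage points apart, within the scatter of two such steps. Going by these compounds alone, all four steps lie within the scatter, so the agreement shows only that neither change gives a readable step on either core; it does not show that either change has a real effect, or that the same would hold on other cores.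

Still open, on these data alone, is whether an open-chain amine in place of piperidin-1-yl, or a longer chain in place of the (benzyloxycarbonyl)methyl group, would give a step beyond the scatter.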